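A Furan Replaces the Chlorophenyl on a Dienone Chain

The compounds below may be only part of what the source reports. "The series", "measured", "known", "first", "only" and "open" are said of these compounds alone.

Among the compounds with values here, compound 1 `CC1=C(/C=C/C(=O)/C=C/c2ccc(Cl)cc2)C(C)(C)CCC1` is the only compound here with a number rather than a limit in a functional assay on HeLa cells (Homo sapiens) for cytotoxicity, read by sulforhodamine B assay, with a stated time of 48 h; a higher number here means a weaker inhibitor, a lower number a stronger inhibitor: compound 1 gives 33200 nM. Compound 2 `CC1=C(/C=C/C(=O)/C=C/c2ccc(Cl)c(Cl)c2)C(C)(C)CCC1` reaches only a limit of > 100000 nM in this assay, which is the limit of > 100000 nM in this assay, at which 1 of the 2 values shown sits. Within the data shown here, the one measured step, an at least 3.0-fold higher number from compound 1 to compound 2 (0.47 log units; beyond the scatter), concerns a different change from the one now followed. Compound 3 `CC1=C(/C=C/C(=O)/C=C/c2ccoc2)C(C)(C)CCC1` differs from compound 1 by furan-3-yl in place of 4-chlorophenyl on a double-bonded chain carbon bound to a double-bonded chain carbon. Among the measured compounds shown here, no measured step bears on this change, so the expectation rests on the weak level of compound 1, 33200 nM, alone. Compound 3 is expected to give 50000 nM, within 15000 nM to 150000 nM. The expected step of a 1.5-fold higher number from compound 1 to compound 3 (0.18 log units; within the scatter) is therefore none beyond the scatter, with a limit possible.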

Compound 3, half-maximal inhibitory concentration: 88400 nM
Beside the measured number, compound 3's estimate is 1.8-fold (0.25 log units) below it; low and high end bracket the measured number.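

In this assay, the aromatic ring itself proves to matter at this place: furan-3-yl in place of 4-chlorophenyl gives a 2.7-fold higher number from compound 1 to compound 3 (0.43 log units; beyond the scatter), whereas the earlier step only added chloro to the ring. Compound 3 still gives a number, so a five-membered aromatic ring with 1 hetero atom keeps a measurable value here. Compound 2 remains a limit, not a number: the limit of > 100000 nM in this assay, at which 1 of the 3 values shown sits.

On these data alone, whether the higher number follows from the furan-3-yl itself or from the loss of chloro, which a plain phenyl at this place would separate, stays open. So does the effect of an amine or a carboxylic acid on the ring.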